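From 2-methylbenzyl to 2-fluorobenzyl: what to expect

The compounds below may be only part of what the source reports. "The series", "measured", "known", "first", "only" and "open" are said of these compounds alone.

Measured in a functional assay on HeLa cells (Homo sapiens) for cytotoxicity, read by MTT assay, with a stated time of 48 h; on this read-out higher numbers stand for weaker inhibition and lower numbers for stronger inhibition:
- compound 1 `Cc1ccccc1Cn1cc(COc2ccc3c(=O)ccoc3c2)nn1`: 15300 nM
- compound 2 `O=c1ccoc2cc(OCc3cn(Cc4cccc([N+](=O)[O-])c4)nn3)ccc12`: 17300 nM
- compound 3 `O=c1ccoc2cc(OCc3cn(Cc4ccccc4Cl)nn3)ccc12`: > 100000 nM, a limit and not a number

Only compound 1 and compound 2 give actual numbers, and these two agree, with a 1.1-fold higher number from compound 1 to compound 2 (0.05 log units; within the scatter). Compound 1 therefore stands level with compound 2 and clear of compound 3.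

Compound 4 `O=c1ccoc2cc(OCc3cn(Cc4ccccc4F)nn3)ccc12` has not yet been measured. It differs from compound 1 in one place: fluoro in place of methyl on an aromatic carbon. This is fluoro in place of methyl on an aromatic carbon, which turns 2-methylphenyl into 2-fluorophenyl.

The closest guide is the swap of chloro in place of methyl, which gave an at least 6.5-fold higher number from compound 1 to compound 3 (0.81 log units; beyond the scatter). On these data alone, that step ends at a limit, so its true size is unknown. The step of an at least 5.7-fold higher number from compound 2 to compound 3 (0.76 log units; beyond the scatter) ends at the same limit and points the same way. Compound 2 goes against any simple trend, since its different group left the number unchanged within the scatter. A rise is therefore expected in this assay, but a smaller one than the chloro swap gave, and staying close to compound 1 remains possible. The expected size is a 2.0-fold higher number from compound 1 to compound 4 (0.29 log units; within the scatter). For compound 4 the estimated value is 30000 nM, with an expected range of 10000 nM to 100000 nM.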

Compound 4, half-maximal inhibitory concentration: > 100000 nM
Compound 4 was reported as a limit; the forecaster's own chance of this, stated with the estimate: 20%; middle value at least 3.3-fold (0.52 log units) away from the limit.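

In this assay, the result shows that the loss seen with chloro is not unique to that atom, since fluoro in place of methyl on this aromatic carbon gives an at least 6.5-fold higher number from compound 1 to compound 4 (0.81 log units; beyond the scatter). Compound 2, which carries 3-nitrophenyl and no halogen, also keeps a readable number where the 2-fluorophenyl group does not, as an at least 5.7-fold higher number from compound 2 to compound 4 (0.76 log units; beyond the scatter) shows, so among these compounds both halogens at this place go with a loss, while methyl and the differently placed nitro group do not. The step between compound 3 and compound 4 cannot be read, and neither halogen can be ranked against the other, since each compound gives only a limit and not a number: the limit of > 100000 nM in this assay, at which 2 of the 4 values shown sit.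

On these data alone, the true size of the loss with fluoro stays unknown, and so does whether any compound of this kind with a halogen at this place would give a readable number at higher concentrations. As far as these compounds go, how a methoxy group, an ethyl group or an amine in place of methyl on this same aromatic carbon would read also remains open.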